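A carboxyphenyl sulfonamide tried on the shared core

This account rests on a few compounds, and the source may have more. Where it says the series, first, only, none or still open, it means among the compounds named here.

Of the compounds shown here, three on a shared core have been measured so far.

Compound 1, `CCOCCS(=O)(=O)N[C@@H](CNC(=O)c1ccc2c(c1)C(=O)N(CCC1CCNCC1)C2)C(=O)O`: in a functional assay for inhibition, with Homo sapiens as the target (on this read-out higher numbers stand for weaker inhibition and lower numbers for stronger inhibition), compound 1 gives 8 nM.
Compound 2, `O=C(NCc1ccccc1)N[C@@H](CNC(=O)c1ccc2c(c1)C(=O)N(CCC1CCNCC1)C2)C(=O)O`: in this assay compound 2 gives 10 nM.
Compound 3, `O=C(NC[C@H](NS(=O)(=O)Cc1ccccc1)C(=O)O)c1ccc2c(c1)C(=O)N(CCC1CCNCC1)C2`: in this assay compound 3 gives 4 nM.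

Compound 1 stands second highest of the three numbers, and it lies within the scatter of both others, with a 1.3-fold higher number from compound 1 to compound 2 (0.10 log units; within the scatter) and a 2.0-fold lower number from compound 1 to compound 3 (0.30 log units; within the scatter). Going by the values given here, the only step beyond the scatter is a 2.5-fold lower number from compound 2 to compound 3 (0.40 log units; beyond the scatter), and it is modest.

Compound 4, `O=C(O)c1ccc(S(=O)(=O)N[C@@H](CNC(=O)c2ccc3c(c2)C(=O)N(CCC2CCNCC2)C3)C(=O)O)cc1`, has not yet been measured. It differs from compound 1 in one place: 4-carboxyphenyl in place of 2-ethoxyethyl on a sulfonyl sulfur. The sulfonyl on the amine nitrogen is kept, and an aromatic ring now sits directly on the sulfonyl sulfur. The step that bears most on this is a 2.0-fold lower number from compound 1 to compound 3 (0.30 log units; within the scatter), where phenyl entered on a saturated chain carbon bound to a sulfonyl sulfur and the number hardly moved. Among the compounds with values here, no measured step covers the carboxylic acid that enters with the 4-carboxyphenyl group, so the range is set wide. The step of no change at the digits printed from compound 1 to compound 4 (within the scatter) is expected to stay within the scatter. Compound 4 is therefore estimated at 8 nM, between 3 nM and 25 nM.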

Compound 4, half-maximal inhibitory concentration: 7 nM
For compound 4 the middle estimate is 1.1-fold (0.06 log units) above the measured one, within the range that was stated.
By their numbers in this assay, from the lowest: compounds 3, 4, 1 and 2 (each within the scatter of the next, the first and the last beyond it).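

Going by these compounds alone, replacing 2-ethoxyethyl with 4-carboxyphenyl on the sulfonyl sulfur gives a 1.1-fold lower number from compound 1 to compound 4 (0.06 log units; within the scatter), so this position holds its number with an aromatic ring bound directly to the sulfur and a carboxylic acid on that ring, neither of which the earlier compounds carried there. Against benzyl on the same sulfur, the 4-carboxyphenyl group gives a 1.8-fold higher number from compound 3 to compound 4 (0.24 log units; within the scatter), and against benzylcarbamoyl on the amine nitrogen, the (4-carboxyphenyl)sulfonyl group gives a 1.4-fold lower number from compound 2 to compound 4 (0.15 log units; within the scatter), so none of the three new steps leaves the scatter. Nothing measured here offers an explanation for these small steps.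

On these data alone, what a plain phenyl group on the sulfonyl sulfur would give remains open, so the part played by the carboxylic acid cannot be separated from that of the aromatic ring. As far as these compounds go, it is also open whether a primary amide or an amine in place of that carboxylic acid, or a longer chain on the sulfonyl sulfur, would keep the number within the same scatter.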